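The compounds below may be only part of what the source reports. "The series", "measured", "known", "first", "only" and "open" are said of these compounds alone.

Values from an ADME assay on MT4 cells (Homo sapiens) for cytotoxicity, read by MTT assay (on this read-out lower numbers stand for higher toxicity in this test and higher numbers for lower toxicity in this test), stand as follows

Compound 1 `O=C1c2ccccc2C(=O)N1CCOC(=S)N(C(=O)c1ccc([N+](=O)[O-])cc1)c1ccc(Cl)cc1` gives > 100000 nM
Compound 2 `Cc1ccc(C(=O)N(C(=S)OCCN2C(=O)c3ccccc3C2=O)c2ccc(C)cc2)cc1` gives 83000 nM
Compound 3 `Cc1ccc(N(C(=O)c2ccc([N+](=O)[O-])cc2)C(=S)OCCN2C(=O)c3ccccc3C2=O)cc1` gives 58000 nM

Compound 1 stands at the limit of > 100000 nM in this assay, at which 1 of the 3 values shown sits, and that is a limit, not a number. Compound 4 `O=C1c2ccccc2C(=O)N1CCOC(=S)N(C(=O)c1ccc(Cl)cc1Cl)c1ccc(Cl)cc1` is still unmeasured, and it has 2,4-dichlorophenyl in place of 4-nitrophenyl on a carbonyl carbon as its difference from compound 1. For the measured compounds named here, two measured steps bear on this: a 1.4-fold lower number from compound 2 to compound 3 (0.16 log units; within the scatter) for nitro in place of methyl on an aromatic carbon, and an at least 1.7-fold lower number from compound 1 to compound 3 (0.23 log units; that floor lies within the scatter) for methyl in place of chloro on an aromatic carbon. Both stay within the scatter. In this assay no step beyond the scatter is therefore expected, only a slight lean towards a lower number. The expected change is an at least 1.5-fold lower number from compound 1 to compound 4 (0.18 log units; that floor lies within the scatter) on this estimate. Compound 4 is estimated at 65000 nM and expected between 30000 nM and 100000 nM on this estimate.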

Compound 4, half-maximal cytotoxic concentration: 18000 nM
Estimate against measurement, compound 4: 3.6-fold (0.56 log units) above, outside the stated range (below it).
By their numbers in this assay, from the lowest: compound 4; then compounds 3 and 2 (each within the scatter of the next). At a limit, above all of these: compound 1.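

On the carbonyl carbon, 2,4-dichlorophenyl in place of 4-nitrophenyl gives an at least 5.5-fold lower number from compound 1 to compound 4 (0.74 log units; beyond the scatter) in this assay, the only step shown that lies beyond the scatter. This group on the carbonyl carbon can therefore move the number clearly, which the nitro and methyl exchange there did not show. The size of the step is only a floor, since compound 1 stands at a limit: the limit of > 100000 nM in this assay, at which 1 of the 4 values shown sits.

The compounds shown leave open whether the loss of nitro or the entry of the two chlorines carries the step. Going by these compounds, how an amine or a carboxylic acid on that phenyl ring would read in this assay also remains open.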